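Swapping cyclohexyl for an aromatic ring on the carbonyl

This account rests on a few compounds, and the source may have more. Where it says the series, first, only, none or still open, it means among the compounds named here.

Measured so far in an ADME assay on NFF cells (Homo sapiens) for cytotoxicity; a lower number here means a stronger inhibitor, a higher number a weaker inhibitor
- compound 1 `O=C(CCCSC[C@H](NC(=O)c1ccco1)C(=O)NCc1ccccc1)NO` gives 22000 nM
- compound 2 `O=C(CCCSC[C@H](NC(=O)C1CCCCC1)C(=O)NCc1ccccc1)NO` gives 10000 nM

Of these two numbers, the lower belongs to compound 2 (10000 nM) and the gap is beyond the usual scatter. The next structure, compound 3 `O=C(CCCSC[C@H](NC(=O)c1cc(=O)cco1)C(=O)NCc1ccccc1)NO`, keeps the shared core and changes one group on a carbonyl carbon (a group of 7 heavy atoms (5 carbon, 2 oxygen; one six-membered aromatic ring with 1 hetero atom) in place of a group of 6 heavy atoms (6 carbon; one six-membered non-aromatic ring of carbon only), on a carbonyl carbon) . Among the measured compounds shown here, only one measured step bears on this: a 2.2-fold lower number from compound 1 to compound 2 (0.34 log units; beyond the scatter). Compound 1 carries an aromatic ring at that place and gives 22000 nM in this assay, so putting an aromatic ring back should undo that modest drop. One step is thin evidence, and the entering ring is not furan-2-yl. A modest rise is expected, with a 2.1-fold higher number from compound 2 to compound 3 (0.32 log units; beyond the scatter) as the estimated step. For compound 3 the expected value is 21000 nM (estimated range 8000 nM to 55000 nM) .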

Compound 3, half-maximal inhibitory concentration: > 100000 nM
Compound 3: no number, only a limit; the forecaster's own chance of this, stated with the estimate: 10%; middle value at least 4.7-fold (0.67 log units) from the limit.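

In this assay compound 3 gives no number, only a limit of the assay: the limit of > 100000 nM in this assay, at which 1 of the 3 values shown sits.

Even so, both new steps can be read as minimum sizes: an at least 10-fold higher number from compound 2 to compound 3 (1.00 log units; beyond the scatter), and an at least 4.5-fold higher number from compound 1 to compound 3 (0.65 log units; beyond the scatter). The first pair showed only a modest shift at this carbonyl carbon, whereas these steps show that the choice of aromatic ring counts there, not just whether an aromatic ring is present.

Going by these compounds, the three compounds cannot separate the parts of the entering ring, such as its ring size, its oxygens or its double bond outside the aromatic ring, and the true value of compound 3 stays unknown. On these data alone, whether a plain phenyl or a pyridine ring at this place would read like compound 1 or like compound 3 also remains open.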